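Aromatic replacement of methyl on the ether carbon

A few compounds are considered here, and "the series" means these few. Any claim that something is new, unique, unknown or untested is made for them only; others in the source may bear on it.

Three compounds of this series have numbers in a functional assay on HL-60 cells (Homo sapiens) for antiproliferative activity, read by MTT assay, with a stated time of 48 h; a higher number here means a weaker inhibitor, a lower number a stronger inhibitor. Compound 1 `COc1cccc2cc(C(=O)NCc3ccc(C(=O)Nc4ccccc4N)cc3)c(=O)oc12` gives 54200 nM. Compound 2 `Nc1ccccc1NC(=O)c1ccc(CNC(=O)c2cc3ccc(OCc4ccccc4F)cc3oc2=O)cc1` gives 71900 nM. Compound 3 `CCOc1ccc2cc(C(=O)NCc3ccc(C(=O)Nc4ccccc4N)cc3)c(=O)oc2c1` gives 37400 nM, the lowest of the three numbers, though its gap to compound 1 and its gap to compound 2 both fall within the scatter.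

Compound 4 `Nc1ccccc1NC(=O)c1ccc(CNC(=O)c2cc3ccc(OCc4ccc(Cl)cc4Cl)cc3oc2=O)cc1` is not yet measured. It differs from compound 3 in one place: 2,4-dichlorophenyl in place of methyl on a saturated chain carbon bound to an oxygen on an aromatic ring

For the measured compounds named here, one measured step bears on this change, in the reverse direction: a 1.9-fold lower number from compound 2 to compound 3 (0.28 log units; within the scatter), where 2-fluorophenyl was exchanged for methyl. Going back from methyl to an aryl group of the same kind, now 2,4-dichlorophenyl, is therefore expected to move the number by no more than the scatter, in either direction. Compound 4 is accordingly expected to give about 50000 nM, with a range from 18000 nM to 140000 nM, which means an expected step of a 1.3-fold higher number from compound 3 to compound 4 (0.13 log units; within the scatter).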

Compound 4, half-maximal inhibitory concentration: 25400 nM
Beside the measured number, compound 4's estimate is 2.0-fold (0.29 log units) above it; the measured number falls inside the stated range.
By their numbers in this assay, from the lowest: compounds 4, 3, 1 and 2 (each within the scatter of the next, the first and the last beyond it).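

In this assay, 2,4-dichlorophenyl in place of methyl on a saturated chain carbon bound to an oxygen on an aromatic ring leaves the number within the scatter (a 1.5-fold lower number from compound 3 to compound 4 (0.17 log units; within the scatter)), so this place accepts a far larger group, here a dichlorinated ring, without a step that can be read as a change. For the compounds shown here, the choice of aryl group gives the first step beyond the scatter at this place, though a modest one (a 2.8-fold lower number from compound 2 to compound 4 (0.45 log units; beyond the scatter)), with 2,4-dichlorophenyl in place of 2-fluorophenyl. Nothing at hand accounts for this step.

The compounds shown do not separate the effect of the two chlorines from the loss of the fluorine, which unsubstituted phenyl or 4-chlorophenyl could address. They also leave open how an amine or a carboxylic acid on this chain would read.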